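The source may report more compounds than this note shows. Statements on the series, on what has been measured and on what is new or still open speak of the compounds shown alone.

The measured compounds:

compound 1, `CCOC(=O)c1c(-c2cccc(-c3ccccc3)c2)[nH]c2cc(Cl)c(OC)cc2c1=O` — > 21500 nM
compound 2, `CCOC(=O)c1c(-c2cccc(OC)c2)[nH]c2cc(Cl)c(OC)cc2c1=O` — > 21500 nM
compound 3, `CCOC(=O)c1c(-c2cccc(-c3ccccc3)c2)[nH]c2cc(OC)c(F)cc2c1=O` — > 21500 nM

In an ADME assay on Raji cells (Homo sapiens) for cytotoxicity, read by luminescence, with a stated time of 72 h (a higher number here means that more compound is needed for the effect, a lower number that less compound is needed), compound 1 gives > 21500 nM, which is a limit of the assay and not a number. Compound 2 likewise gives > 21500 nM, a limit. Compound 3 gives > 21500 nM, again a limit. Compound 1 and compound 2 differ by methoxy in place of phenyl on an aromatic carbon, and the step that the two limits leave unreadable from compound 1 to compound 2 cannot be read, since both values are limits; this rests on (the limit of > 21500 nM in this assay, at which 3 of the 3 values shown sit). How the core of compound 1 differs from the core of compound 3 is not broken down here.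

Compound 4, `CCOC(=O)c1c(-c2cccc(OC)c2)[nH]c2cc(OC)c(F)cc2c1=O`, has not yet been measured in this assay. It differs from compound 3 by methoxy in place of phenyl on an aromatic carbon, the same change as that from compound 1 to compound 2, made at a place described in the same words. Since that earlier pair gave no readable step, the step that the limit leaves unreadable from compound 3 to compound 4 is expected to be small and probably unreadable as well. Compound 4 is therefore estimated at 30000 nM, between 12000 nM and 100000 nM, most likely reported again as a limit.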

Compound 4, half-maximal effective concentration: > 21500 nM
Compound 4 was reported as a limit; the forecaster's own chance of this, stated with the estimate: 85%; the middle value is on the limit's open side.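

In this assay compound 4 gives > 21500 nM, which is a limit of the assay and not a number. No step can be read between compound 3 and compound 4, since both values are limits: the limit of > 21500 nM in this assay, at which 4 of the 4 values shown sit.

The compounds shown leave open how much of any of them is needed for the effect in this assay, and whether methoxy in place of phenyl changes that amount.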